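The source may report more compounds than this note shows. Statements on the series, on what has been measured and on what is new or still open speak of the compounds shown alone.

The compounds measured so far, with their results in a functional assay on MCF7 cells (Homo sapiens) for inhibition, read by sulforhodamine B assay, with a stated time of 48 h; a lower number here means a stronger inhibitor of growth, a higher number a weaker inhibitor of growth:

Compound 1, `S=C(N/N=C/c1cccs1)Nc1ccccc1`: 94600 nM
Compound 3, `Cc1ccc(NC(=S)N/N=C/c2cccs2)cc1`: 38600 nM
Compound 2, `S=C(N/N=C/c1cccs1)Nc1cccnc1`, reaches only the limit of this assay, > 100000 nM.

For the measured compounds named here, compound 3 holds the lowest of the two numbers given; its nearest neighbour is compound 1, and the step of a 2.5-fold lower number from compound 1 to compound 3 (0.39 log units; beyond the scatter) is the only change that has been measured with a number at both ends. The next compound, compound 4, `CCc1ccc(NC(=S)N/N=C/c2cccs2)cc1`, carries a single alteration relative to compound 3: methyl in place of hydrogen on a saturated chain carbon bound to an aromatic carbon. Going by the values given here, the one measured step that bears on this change is the addition of a methyl on the aromatic carbon, which gave a modest lowering in this assay. Adding one more carbon at the same place is a smaller kind of change, so the expectation is for little movement: a step of a 1.3-fold lower number from compound 3 to compound 4 (0.11 log units; within the scatter) that stays close to the scatter, perhaps leaning toward a lower number. Compound 4 is therefore estimated at 30000 nM, within a range from 12000 nM to 75000 nM.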

Compound 4, concentration for 50% growth inhibition: > 100000 nM
Compound 4: no number, only a limit; the forecaster's own chance of this, stated with the estimate: 5%; middle value at least 3.3-fold (0.52 log units) away from the limit.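

Extending the methyl of compound 3 to an ethyl gives an at least 2.5-fold higher number from compound 3 to compound 4 (0.41 log units; beyond the scatter), so the lowering seen with methyl does not continue when the group grows by one carbon. Ethyl in place of hydrogen on the aromatic carbon gives an at least 1.0-fold higher number from compound 1 to compound 4 (0.02 log units; that floor lies within the scatter), so no gain over hydrogen can be read from this pair. The result for compound 4 in this assay is a limit and not a number, and compound 2 stops at the same limit: the limit of > 100000 nM in this assay, at which 2 of the 4 values shown sit.

As far as these compounds go, how far the true value of compound 4 lies past that limit stays open, and one change cannot show what drives the loss. From the compounds shown here alone, it is also open whether a chlorine atom, a methoxy group or a longer chain at the same place would behave like methyl or like ethyl.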